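The compounds below may be only part of what the source reports. "The series", "measured", "known", "first", "only" and "open" are said of these compounds alone.

Measured compounds:
compound 1, `CCCCSc1n[nH]c(-n2[se]c3ccccc3c2=O)n1`, which in a functional assay on SMMC-7721 cells (Homo sapiens) for antiproliferative activity, read by CCK-8 assay, with a stated time of 48 h (on this read-out lower numbers stand for stronger inhibition and higher numbers for weaker inhibition), gives 16800 nM
compound 2, `CCSc1n[nH]c(-n2[se]c3ccccc3c2=O)n1`, which in this assay gives 10000 nM
compound 3, `CCCCCSc1n[nH]c(-n2[se]c3ccccc3c2=O)n1`, which in this assay gives 31400 nM

The three compounds share one core and differ only in the chain attached to the sulfur. Compound 2 is obtained from compound 1 by the change (hydrogen in place of ethyl on a saturated chain carbon, two bonds along the chain from a sulfur), and this gives a 1.7-fold lower number from compound 1 to compound 2 (0.23 log units; within the scatter). Compound 3 is obtained from compound 1 by the change (methyl in place of hydrogen on a saturated chain carbon, four bonds along the chain from a sulfur), which gives a 1.9-fold higher number from compound 1 to compound 3 (0.27 log units; within the scatter). Between the two ends of the series the gap is larger: a 3.1-fold higher number from compound 2 to compound 3 (0.50 log units; beyond the scatter).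

Compound 4, `CCCSc1n[nH]c(-n2[se]c3ccccc3c2=O)n1`, has not yet been measured in this assay. It is obtained from compound 3 by the change (hydrogen in place of ethyl on a saturated chain carbon, three bonds along the chain from a sulfur). Going by the values given here, this is the same kind of change as the one from compound 1 to compound 2, but the place is not the same: there the change sits two bonds along the chain from a sulfur, here three bonds along the chain from a sulfur. The step from compound 3 to compound 4 is expected to be of about the same size as the earlier one, a 2.3-fold lower number from compound 3 to compound 4 (0.37 log units; beyond the scatter), because compound 1 to compound 2 gave a 1.7-fold lower number from compound 1 to compound 2 (0.23 log units; within the scatter), and because compound 2 with 10000 nM marks where the shorter chains in this series lie. Compound 4 is therefore estimated at 13500 nM in this assay, with an expected range from 7000 nM to 26000 nM.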

Compound 4, half-maximal inhibitory concentration: 6020 nM
Compound 4: middle estimate off by 2.2-fold (0.35 log units), on the high side; measured number below the stated range.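

In this assay, the loss of the ethyl end of the chain gives a 5.2-fold lower number from compound 3 to compound 4 (0.72 log units; beyond the scatter), so the step seen on the shorter chain does not carry over at the same size: the same change on two cores in this assay, a 1.7-fold lower number (0.23 log units; within the scatter) from compound 1 to compound 2 and a 5.2-fold lower number (0.72 log units; beyond the scatter) from compound 3 to compound 4, 3.1-fold (0.49 log units) apart, beyond the scatter of two such steps. The addition of a methyl at the chain end also differs between the two chains, with a 1.7-fold lower number from compound 2 to compound 4 (0.22 log units; within the scatter) set against the earlier step on the butyl chain: the same change on two cores in this assay, a 1.9-fold higher number (0.27 log units; within the scatter) from compound 1 to compound 3 and a 1.7-fold lower number (0.22 log units; within the scatter) from compound 2 to compound 4, 3.1-fold (0.49 log units) apart, beyond the scatter of two such steps. Replacing the methyl end of the butyl chain with hydrogen gives a 2.8-fold lower number from compound 1 to compound 4 (0.45 log units; beyond the scatter), which stands beyond the scatter, while compound 4 and compound 2 remain within it, so in this series the size of a chain change depends on the chain that carries it, but four compounds do not show why or give a rule for predicting it.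

The compounds shown carry only unbranched chains from ethyl to pentyl on the sulfur of the shared core, so it remains open how a methyl, a longer chain or a branched chain would read. Also open, on these data alone, is whether a chain ending in an amine or a carboxylic acid would fit the same steps.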